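Indole to Dihydroxyphenyl on the Hydrazone Carbon of a Urea

The source may hold more compounds than are shown below. What is called first, only, known or untested is meant among the compounds shown, and "the series" means these compounds.

Measured compounds:
- Compound 1, `CN(C)CCn1cnnc1-c1cc(Oc2ccc(NC(=O)N/N=C/c3c[nH]c4ccccc34)cc2F)ccn1`: 820 nM
- Compound 2, `COc1ccc(/C=N/NC(=O)Nc2ccc(Oc3ccnc(-c4nncn4CCN(C)C)c3)c(F)c2)c(OC)c1`: 2820 nM
- Compound 3, `CN(C)CCn1cnnc1-c1cc(Oc2ccc(NC(=O)N/N=C/c3ccc(O)c(Br)c3)cc2F)ccn1`: 1370 nM

In a functional assay on A549 cells (Homo sapiens) for cytotoxicity, read by MTT assay, with a stated time of 72 h (on this read-out lower numbers stand for stronger inhibition and higher numbers for weaker inhibition), compound 1 gives the lowest of the three numbers; compound 3 stands nearest, with a 1.7-fold higher number from compound 1 to compound 3 (0.22 log units; within the scatter), and compound 2 furthest, with a 3.4-fold higher number from compound 1 to compound 2 (0.54 log units; beyond the scatter). Compound 4, `CN(C)CCn1cnnc1-c1cc(Oc2ccc(NC(=O)N/N=C/c3ccc(O)cc3O)cc2F)ccn1`, has not been measured. It differs from compound 1 in one place: 2,4-dihydroxyphenyl in place of 1H-indol-3-yl on a carbon with a double bond to nitrogen. Going by the values given here, the steps that bear on this are the two exchanges of the same group on compound 1, which gave a 3.4-fold higher number from compound 1 to compound 2 (0.54 log units; beyond the scatter) and a 1.7-fold higher number from compound 1 to compound 3 (0.22 log units; within the scatter). Both moved the number upward, one modestly and one within the scatter, so a modest upward step is expected here as well, a 1.8-fold higher number from compound 1 to compound 4 (0.26 log units; within the scatter). Compound 4 is therefore estimated at 1500 nM, in a range from 600 nM to 4000 nM.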

Compound 4, half-maximal inhibitory concentration: 12700 nM
Beside the measured number, compound 4's estimate is 8.5-fold (0.93 log units) below it; measured number above the stated range.
By their numbers in this assay, from the lowest: compounds 1 and 3 (each within the scatter of the next); then compound 2; then compound 4.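

Replacing 1H-indol-3-yl with 2,4-dihydroxyphenyl gave a 15-fold higher number from compound 1 to compound 4 (1.19 log units; beyond the scatter) in this assay and showed that this carbon with a double bond to nitrogen does not accept every aromatic group equally. The change of substituents on the phenyl ring also mattered, with a 9.3-fold higher number from compound 3 to compound 4 (0.97 log units; beyond the scatter) and a 4.5-fold higher number from compound 2 to compound 4 (0.65 log units; beyond the scatter) setting compound 4 apart from both other phenyl compounds. No evidence is available to explain this drop.

The compounds shown leave open how a 4-hydroxyphenyl, a 2-hydroxyphenyl or a 2,4-diaminophenyl group would read at this carbon. They also leave open whether a single hydroxyl group would carry the same penalty as two.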